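The source may report more compounds than this note shows. Statements on the series, on what has been measured and on what is new or still open speak of the compounds shown alone.

Compound 1 `CC1(C)C=C(n2ccccc2=O)c2cc(C(=O)c3ccc(O)cc3)ccc2O1` and compound 2 `CC1(C)C=C(n2ccccc2=O)c2cc(O)ccc2O1` share a core and differ at one aromatic carbon. Going by the values given here, in a functional assay (aorta) with Rattus norvegicus as the target (on this read-out higher numbers stand for higher potency (the scale is a negative logarithm) and lower numbers for lower potency), compound 1 gives 6.65, while compound 2 gives 5.44, the lower of the two numbers known so far; the only measured step, a number 1.21 log units lower from compound 1 to compound 2 (beyond the scatter), shows how much that swap cost. Compound 3 `CC(=O)Oc1ccc2c(c1)C(n1ccccc1=O)=CC(C)(C)O2` keeps the core of compound 2 and changes only the oxygen on the aromatic ring: acetyl in place of hydrogen on an oxygen on an aromatic ring. Among the compounds with values here, no measured step describes this kind of change, and the step from compound 1 to compound 2 speaks to a different position and a different group, so it gives little direct guidance. Compound 3 is therefore expected to stay close to compound 2, with an estimated step of a number 0.16 log units higher from compound 2 to compound 3 (within the scatter) in this assay. The estimate for compound 3 in this assay is 5.6, ranging from 5 to 6.3.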

Compound 3, logarithm of the reciprocal of the active concentration, log(1/C): 5.6
For compound 3 middle estimate and measured number coincide at the digits printed; the measured number falls inside the stated range.
By their numbers in this assay, from the lowest: compounds 2 and 3 (each within the scatter of the next); then compound 1.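

In this assay, putting acetyl on the oxygen on the aromatic ring gives a number 0.16 log units higher from compound 2 to compound 3 (within the scatter), so hydroxy and acetoxy cannot be told apart on this read-out, and the hydrogen on that oxygen can be replaced by acetyl with no difference beyond the scatter. The second comparison, a number 1.05 log units lower from compound 1 to compound 3 (beyond the scatter), shows that the large gap to the (4-hydroxyphenyl)carbonyl group remains with acetoxy in its place, as it did with hydroxy. Nothing available here explains either number.

The compounds shown leave open whether a longer chain on that oxygen, such as a hexanoyl group, would also stay within the scatter of compound 2. They also leave open how an amine or a carboxylic acid on the same aromatic carbon would compare with the (4-hydroxyphenyl)carbonyl group of compound 1.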